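Amide ring variation in a cathepsin S nitrile series

The compounds below may be only part of what the source reports. "The series", "measured", "known", "first", "only" and "open" are said of these compounds alone.

compound 1 `N#CC1(NC(=O)[C@@H]2C[C@@H](S(=O)(=O)c3ccccc3)C[C@H]2C(=O)N2CCOCC2)CC1` — 0.7 nM
compound 2 `N#CC1(NC(=O)[C@@H]2C[C@@H](S(=O)(=O)c3ccccc3)C[C@H]2C(=O)N2CC3(COC3)C2)CC1` — 3 nM

In an assay on isolated protein for inhibition of cathepsin S (Homo sapiens), read by fluorescence, with a stated time of 20 min (on this read-out higher numbers stand for weaker inhibition and lower numbers for stronger inhibition), compound 2 gives 3 nM, the higher of the two numbers, while compound 1 gives 0.7 nM. Compound 3 `N#CC1(NC(=O)[C@@H]2C[C@@H](S(=O)(=O)c3ccccc3)C[C@H]2C(=O)N2CCCCC2)CC1` differs from compound 2 by a group of 6 heavy atoms (5 carbon, 1 nitrogen; one six-membered non-aromatic ring with 1 hetero atom) in place of a group of 7 heavy atoms (5 carbon, 1 nitrogen, 1 oxygen; 2 four-membered non-aromatic rings with 1 hetero atom each), on a carbonyl carbon. For the measured compounds named here, the only step that touches this carbonyl carbon, a 4.3-fold higher number from compound 1 to compound 2 (0.63 log units; beyond the scatter), was modest. Because compound 1 gives 0.7 nM with a six-membered ring at the same place, compound 3 is expected to move back in that direction, by a 2.0-fold lower number from compound 2 to compound 3 (0.30 log units; within the scatter). Compound 3 is estimated at 1.5 nM, with a range of 0.5 nM to 5 nM.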

Compound 3, half-maximal inhibitory concentration: 0.8 nM
Compound 3: the middle estimate sits 1.9-fold (0.27 log units) above what was measured; low and high end bracket the measured number.
By their numbers in this assay, from the lowest: compounds 1 and 3 (each within the scatter of the next); then compound 2.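

In this assay, piperidin-1-yl in place of morpholin-4-yl on this carbonyl carbon gives a 1.1-fold higher number from compound 1 to compound 3 (0.06 log units; within the scatter), so these two six-membered rings are not told apart here. The same piperidin-1-yl group, set against the group with two four-membered rings, gives a 3.8-fold lower number from compound 2 to compound 3 (0.57 log units; beyond the scatter), which leaves compound 2 alone at the higher number among the three amides. Nothing at hand accounts for either step.

Still open, from the compounds shown here alone, is how pyrrolidin-1-yl, a smaller ring, or piperazin-1-yl, with a second ring nitrogen, would read on this carbonyl carbon. Going by these compounds, an open-chain diethylamino group on the same carbon is equally open.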